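Moving a halogen for a thioether on the urea aryl

The compounds below may be only part of what the source reports. "The series", "measured", "known", "first", "only" and "open" are said of these compounds alone.

Three ureas built on the shared core of compound 1 `O=C(Nc1ccc(I)cc1)N[C@H]1CC[C@H](Oc2ccc(F)cc2)CC1` have been tested in a functional assay on CRL2813 cells (Homo sapiens) for cytotoxicity, read by sulforhodamine B assay, with a stated time of 5 days; on this read-out lower numbers stand for stronger inhibition and higher numbers for weaker inhibition. Compound 1 gives 10200 nM, the highest of the two numbers reported in this assay. Compound 2 `O=C(Nc1cccc(C(F)(F)F)c1)N[C@H]1CC[C@@H](Oc2ccc(F)cc2)CC1` gives 2600 nM in this assay, the lower of the two. Compound 3 `O=C(Nc1ccccc1C(=O)O)N[C@H]1CC[C@@H](Oc2ccc(F)cc2)CC1`, which carries a carboxylic acid on its aryl group, reaches only the limit of this assay, > 20000 nM, so no number is available for it; one of the three results therefore sits at this limit (the limit of > 20000 nM in this assay, at which 1 of the 3 values shown sits).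

Compound 4 `CSc1ccccc1NC(=O)N[C@H]1CC[C@H](Oc2ccc(F)cc2)CC1` has not yet been measured. It differs from compound 1 in one place: 2-(methylsulfanyl)phenyl in place of 4-iodophenyl on an amide-type nitrogen. Both groups are neutral and without hydrogen-bond donors; the entering group brings one hydrogen-bond acceptor where the leaving group had none. For the measured compounds named here, with no measured pair that isolates such a change, the direction can only be guessed. The expectation for compound 4 in this assay is a value near that of compound 1, within or close to the scatter of the measurement, so the step from compound 1 to compound 4 is estimated at a 1.2-fold higher number from compound 1 to compound 4 (0.07 log units; within the scatter). Compound 4 is therefore expected to give about 12000 nM in this assay, with a plausible range from 4000 nM to 30000 nM.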

Compound 4, half-maximal inhibitory concentration: > 20000 nM
Compound 4: only a limit was reported; the forecaster's own chance of this, stated with the estimate: 25%; middle value at least 1.6-fold (0.22 log units) from the limit.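

In this assay compound 4 gives > 20000 nM, which is a limit of the assay and not a number. As far as these compounds go, exchanging 4-iodophenyl for 2-(methylsulfanyl)phenyl on the amide-type nitrogen gives an at least 1.9-fold higher number from compound 1 to compound 4 (0.29 log units; that floor lies within the scatter), so this step has only a floor, that floor lies within the scatter, and its true size stays unknown. The earlier compounds showed a limit only for an aryl group carrying a carboxylic acid, whereas this result shows that an aryl group with no net charge can also leave this assay without a number, and the limit now accounts for more of the set: the limit of > 20000 nM in this assay, at which 2 of the 4 values shown sit.

The step changes both the substituent and its place on the phenyl ring, so the compounds shown do not separate these two changes, and a 4-(methylsulfanyl)phenyl or 2-iodophenyl group on the same nitrogen would be needed to do so. Also open, from the compounds shown here alone, is how an aryl group bearing an amine or a longer thioether chain would read at this position on the core of compound 1.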